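The source may hold more compounds than are shown below. What is called first, only, known or untested is meant among the compounds shown, and "the series" means these compounds.

Working notes on the series. Compound 1 `NC1=NC2(CCSCC2)N(OCCCOc2ccc(Cl)c(Cl)c2)C(N)=N1` gives 1 nM in a functional assay on HCT-116 cells (Homo sapiens) for antiproliferative activity, read by MTT assay, with a stated time of 72 h (on this read-out lower numbers stand for stronger inhibition and higher numbers for weaker inhibition), the lowest of the three numbers. Compound 3 `NC1=NC2(CCOCC2)N(OCCCOc2ccccc2Br)C(N)=N1` gives 30 nM in this assay, and compound 2 `NC1=NC2(CCOCC2)N(OCCCOc2ccc(F)cc2)C(N)=N1` gives 3280 nM. Going by the values given here, the one single-site step measured, 2-bromophenyl in place of 4-fluorophenyl on an oxygen on a saturated carbon, was a 110-fold lower number from compound 2 to compound 3 (2.04 log units; beyond the scatter), showing that the aryl group drives large swings. Compound 4 `NC1=NC2(CCSCC2)N(OCCCOc2cccc(Br)c2)C(N)=N1` differs from compound 1 by 3-bromophenyl in place of 3,4-dichlorophenyl on an oxygen on a saturated carbon. Among the compounds with values here, no measured step covers this exact change; given the size of the aryl effect from compound 2 to compound 3, a weakening step is expected, a 15-fold higher number from compound 1 to compound 4 (1.18 log units; beyond the scatter). Compound 4 is therefore estimated at 15 nM in this assay, within 3 nM to 80 nM.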

Compound 4, half-maximal inhibitory concentration: 1 nM
For compound 4 the middle estimate is 15-fold (1.18 log units) above the measured one, and the stated range ends above it.
By their numbers in this assay, from the lowest: compounds 1 and 4 (each within the scatter of the next); then compound 3; then compound 2.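

The step from 3,4-dichlorophenyl to 3-bromophenyl, no change at the digits printed from compound 1 to compound 4 (within the scatter), means that this assay does not tell these two aryl groups apart on the core of compound 1. Going by these compounds alone, the earlier step, a 110-fold lower number from compound 2 to compound 3 (2.04 log units; beyond the scatter), showed only that an aryl change on an oxygen on a saturated carbon can carry a large difference; this one shows that such a change, here with one heavy atom fewer, can also leave the result within the scatter. No evidence at hand bears on the reason. Open, as far as these compounds go, is whether 3-bromophenyl gives the same result on the core of compound 3, and how an aryl group bearing an amine or a carboxylic acid would read.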